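Aryl replacement of the hexynyl chain in the nucleoside series

A few compounds are considered here, and "the series" means these few. Any claim that something is new, unique, unknown or untested is made for them only; others in the source may bear on it.

Compound 1 `CCCCC#Cc1cc([C@@H]2O[C@H](CO)[C@@H](O)[C@H]2O)n2ncnc(N)c12` gives 200 nM in a functional assay on Z-138 cells (Homo sapiens) for antiproliferative activity, with a stated time of 72 h (on this read-out lower numbers stand for stronger inhibition and higher numbers for weaker inhibition), the lowest number among the compounds with a measured value. Compound 3 `Nc1ncnn2c([C@@H]3O[C@H](CO)[C@@H](O)[C@H]3O)cc(/C=C/c3ccccc3)c12` gives 1300 nM in this assay. Compound 2 `Nc1ncnn2c([C@@H]3O[C@H](CO)[C@@H](O)[C@H]3O)cc(-c3ccccc3)c12` reports only a limit, > 100000 nM. The step of a 6.5-fold higher number from compound 1 to compound 3 (0.81 log units; beyond the scatter) is modest. The step of an at least 500-fold higher number from compound 1 to compound 2 (2.69 log units; beyond the scatter) is large and open-ended because of the limit of > 100000 nM in this assay, at which 1 of the 3 values shown sits. Compound 4 `Nc1ncnn2c([C@@H]3O[C@H](CO)[C@@H](O)[C@H]3O)cc(-c3ccccc3Cl)c12` differs from compound 1 by 2-chlorophenyl in place of hex-1-yn-1-yl on an aromatic carbon. As in compound 2, an aromatic ring stands directly on the core, so the step to compound 2 bears most on it, with compound 3 showing that a two-atom linker recovers part of the activity. A large upward step is therefore expected, a 200-fold higher number from compound 1 to compound 4 (2.30 log units; beyond the scatter). Compound 4 is estimated at 40000 nM, between 4000 nM and 200000 nM.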

Compound 4, half-maximal inhibitory concentration: 76100 nM
Compound 4: the middle estimate sits 1.9-fold (0.28 log units) below what was measured; the range from low to high includes it.
By their numbers in this assay, from the lowest: compound 1; then compound 3; then compound 4. At a limit, above all of these: compound 2.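

With 2-chlorophenyl in place of hex-1-yn-1-yl on this aromatic carbon, a ring standing directly on the core now carries a measured number, and the step is a 380-fold higher number from compound 1 to compound 4 (2.58 log units; beyond the scatter). The 2-phenylethenyl group stays clearly ahead of this directly attached ring, with a 59-fold higher number from compound 3 to compound 4 (1.77 log units; beyond the scatter). The chloro step reads only as a floor, an at least 1.3-fold lower number from compound 2 to compound 4 (0.11 log units; that floor lies within the scatter). Compound 2 is reported only as a limit, so the exact size of this step cannot be read: the limit of > 100000 nM in this assay, at which 1 of the 4 values shown sits.

Going by these compounds, whether a shorter alkynyl chain, or an amine or a hydroxyl at the end of the hexynyl chain, holds the activity of compound 1 remains open. Also open, on these data alone, is how a chloro substituent would act on the ring of compound 3.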